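Swapping Cyclopropylmethoxy for (4-Cyanophenyl)amino on a Shared Core

The compounds below may be only part of what the source reports. "The series", "measured", "known", "first", "only" and "open" are said of these compounds alone.

Measured compounds:
compound 1, `COc1ccc2c(c1)NC(=O)CN2c1nc(NCCCO)nc2ccccc12` — 7.43 nM
compound 2, `COc1ccc2c(c1)NC(=O)CN2c1nc(OCC2CC2)nc2ccccc12` — 7.88 nM

Both compounds were tested in a functional assay on MCF7 cells (Homo sapiens) for inhibition, read by sulforhodamine B assay, with a stated time of 48 h; a higher number here means a weaker inhibitor of growth, a lower number a stronger inhibitor of growth. Compound 1 gives 7.43 nM in this assay, and compound 2 gives 7.88 nM. Among the measured compounds shown here, the only measured step, a 1.1-fold higher number from compound 1 to compound 2 (0.03 log units; within the scatter), lies within the scatter, so compound 2 and compound 1 cannot be told apart on these numbers; compound 2 is simply the one whose value stands higher of the two, with compound 1 as its nearest neighbour.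

Compound 3, `COc1ccc2c(c1)NC(=O)CN2c1nc(Nc2ccc(C#N)cc2)nc2ccccc12`, has not yet been measured in this assay. The change from compound 2 is (4-cyanophenyl)amino in place of cyclopropylmethoxy on an aromatic carbon. For the measured compounds named here, the one measured step concerns a different pair of groups at the same aromatic carbon and was within the scatter, so it offers only weak guidance: it shows that one exchange at this position left the value essentially unchanged. On that basis the step from compound 2 to compound 3 is expected to be small, with no direction favoured beyond the scatter, an expected step of a 1.1-fold lower number from compound 2 to compound 3 (0.05 log units; within the scatter). The estimate for compound 3 is therefore 7 nM, with a range from 2 nM to 25 nM.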

Compound 3, concentration for 50% growth inhibition: 9.19 nM
Beside the measured number, compound 3's estimate is 1.3-fold (0.12 log units) below it, and the stated range covers the measured number.
By their numbers in this assay, from the lowest: compounds 1, 2 and 3 (each within the scatter of the next).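

In this assay, among the compounds shown here, the carbon between two ring nitrogen atoms now also carries a six-membered aromatic ring with a nitrile, whereas the earlier compounds placed only non-aromatic groups there. Even so, the exchange of cyclopropylmethoxy for (4-cyanophenyl)amino gives a 1.2-fold higher number from compound 2 to compound 3 (0.07 log units; within the scatter), and 4-cyanophenyl in place of 3-hydroxypropyl on the nitrogen gives a 1.2-fold higher number from compound 1 to compound 3 (0.09 log units; within the scatter), so neither the larger group nor the aromatic ring separates these compounds on these numbers. No supporting measurement is available to account for this result.

The compounds shown leave open how far this tolerance extends, since all three groups are joined through an oxygen or a nitrogen and none is charged, so a carboxylic acid in place of the nitrile or a morpholine at this carbon could behave differently. They also cannot show whether a value beyond the scatter would appear with a different substituent on the phenyl ring, such as a methoxy group, or with the bare amine at this position.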